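The source may hold more compounds than are shown below. What is called first, only, known or untested is meant among the compounds shown, and "the series" means these compounds.

This account concerns the related ureas compound 1 and compound 2, and also compound 3, which has not yet been measured. Compound 1 `COc1ccccc1C(=O)NC(=O)Nc1ccc(-c2ccccn2)c(C(F)(F)F)c1` carries a pyridin-2-yl group, and in an ADME assay on LLC-PK1 cells (Sus scrofa) for permeability (a higher number here means that the compound crosses the layer faster, a lower number that the compound crosses the layer more slowly), compound 1 gives 7.4 10^-6 cm/s. Compound 2 `COc1ccccc1C(=O)NC(=O)Nc1ccc(-c2ccccc2)c(C(F)(F)F)c1` carries a phenyl group in its place. In this assay compound 2 gives < 1 10^-6 cm/s, which is a limit of the assay and not a number. Going by the values given here, the single measured step is an at least 7.4-fold lower number from compound 1 to compound 2 (0.86 log units; beyond the scatter), and its size is known only through (the limit of < 1 10^-6 cm/s in this assay, at which 1 of the 2 values shown sits). Compound 3 `COc1ccccc1C(=O)NC(=O)Nc1ccc(OCC(F)(F)F)c(C(F)(F)F)c1` differs from compound 2 in one place: 2,2,2-trifluoroethoxy in place of phenyl on an aromatic carbon. Among the compounds with values here, no measured step exchanges a phenyl for a 2,2,2-trifluoroethoxy group, so the one step that exists tells only that compound 2 sits at the limit and gives no direction for the present change. The expected size and direction of the step in this assay are therefore open, and the estimated step is an at least 2.0-fold higher number from compound 2 to compound 3 (0.30 log units; that floor lies within the scatter). Compound 3 is expected to give about 2 10^-6 cm/s, with a range from 0.5 10^-6 cm/s to 8 10^-6 cm/s, and a fair chance that the assay again reports only a limit.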

Compound 3, apparent permeability in the LLC-PK1 assay: < 1 10^-6 cm/s
Compound 3 gave a limit, no number; the forecaster's own chance of this, stated with the estimate: 40%; middle value at least 2.0-fold (0.30 log units) from the limit.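

Going by these compounds alone, in the LLC-PK1 assay compound 3 joins compound 2 at the limit of the read-out, which is a limit and not a number, so a 2,2,2-trifluoroethoxy group in this place has not restored a readable value and compound 1, with its pyridin-2-yl group, remains the only compound with one: the limit of < 1 10^-6 cm/s in the LLC-PK1 assay, at which 2 of the 3 values shown sit. In the LLC-PK1 assay the exchange of pyridin-2-yl for 2,2,2-trifluoroethoxy gives an at least 7.4-fold lower number from compound 1 to compound 3 (0.86 log units; beyond the scatter), whereas the step from phenyl to 2,2,2-trifluoroethoxy cannot be read, as both of its ends are limits. The same exchange can be read on solubility, where in a physicochemical assay for solubility, in simulated intestinal fluid (on this read-out higher numbers stand for higher solubility and lower numbers for lower solubility), compound 2 gives 23 ug/mL and compound 3 gives the lower number, 2.2 ug/mL, a gap beyond the scatter.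

On these data alone, how far compound 2 and compound 3 really lie apart in the LLC-PK1 assay, and whether their solubility has any link to that read-out, stays open. Also open, as far as these compounds go, is whether a morpholine or a pyridin-4-yl group in this place, para to a large group and ortho to the trifluoromethyl group, would give a readable number in the LLC-PK1 assay.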